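Hydroxamate series: chloro for methyl on the aryl ring

A few compounds are considered here, and "the series" means these few. Any claim that something is new, unique, unknown or untested is made for them only; others in the source may bear on it.

Three compounds share one hydroxamic acid core and differ in the group on the ring nitrogen. Compound 1 `CCOc1ccc(CCCN2CC=C(CCC(=O)NO)C2=O)cc1` carries an ethoxyphenylpropyl chain; in a functional assay on HCT-15 cells (Homo sapiens) for inhibition, read by sulforhodamine B assay (on this read-out higher numbers stand for weaker inhibition of growth and lower numbers for stronger inhibition of growth), compound 1 gives 5100 nM. Compound 2 `Cc1ccc(CN2CC=C(CCC(=O)NO)C2=O)cc1` carries a methylbenzyl group; in this assay compound 2 gives 4720 nM. Compound 3 `Cc1ccc(CCCCN2CC=C(CCC(=O)NO)C2=O)cc1` carries a methylphenylbutyl chain; in this assay compound 3 gives 8540 nM. Compound 2 shows the low number of the three on paper, but its gap to compound 1 and its gap to compound 3 both lie within the scatter, so the three do not separate.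

Compound 4 `O=C(CCC1=CCN(Cc2ccc(Cl)cc2)C1=O)NO` is not yet measured. It differs from compound 2 in one place: chloro in place of methyl on an aromatic carbon. Going by the values given here, no measured pair in this set isolates that exchange, so nothing here tells its size. Given how little the three measured compounds move, the expectation for compound 4 is a step of a 1.0-fold lower number from compound 2 to compound 4 (0.02 log units; within the scatter), that is, none beyond the scatter. Compound 4 is therefore estimated at 4500 nM, within 2200 nM to 9500 nM.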

Compound 4, concentration for 50% growth inhibition: 4720 nM
For compound 4 the middle estimate is 1.0-fold (0.02 log units) below the measured one, and the stated range covers the measured number.
By their numbers in this assay, from the lowest: compounds 2, 4, 1 and 3 (each within the scatter of the next).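

In this assay, going by these compounds alone, the exchange of chloro in place of methyl, on the aromatic carbon para to a large group, reads no change at the digits printed from compound 2 to compound 4 (within the scatter) and forms the first measured pair that isolates a single change. On the benzyl group of compound 2, this position therefore takes methyl or chloro with no difference in the read-out. Compound 1 and compound 3 could not show this, as each differs from compound 2 in more than one place. No supporting measurement bears on why the two groups read alike.

Going by these compounds, whether other groups at this position, such as an amine, a carboxylic acid or a methoxy group, read the same stays open. Also open, on these data alone, is whether the exchange behaves alike on the longer methylphenylbutyl chain of compound 3.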